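The source may hold more compounds than are shown below. What is called first, only, known or untested is meant among the compounds shown, and "the series" means these compounds.

Measured compounds:
compound 1, `CCCn1c(=O)[nH]c2nc(-c3ccc(S(=O)(=O)N4CCN(c5cccc(Cl)c5)CC4)cc3)[nH]c2c1=O`, 21%
compound 2, `CCCn1c(=O)c2[nH]c(-c3ccc(S(=O)(=O)N4CCN(c5ccc(Cl)cc5)CC4)cc3)nc2n(CC)c1=O`, 24%
compound 3, `CCCn1c(=O)[nH]c2nc(-c3ccc(S(=O)(=O)N4CCN(c5ccccc5)C(C)C4)cc3)[nH]c2c1=O`, 15%

In an assay on CHO cells for displacement of a labelled ligand from adenosine receptor A1 (Homo sapiens), read by scintillation counting, with a stated time of 90 min, tested at 1 uM, in the presence of a further agent that is not named here (a lower number here means less inhibition, a higher number more inhibition at the concentration tested (going by the name of the read-out)), compound 1 gives 21%, which is the second highest of the three numbers. Compound 2 gives 24%, a number higher than that of compound 1 but within the usual scatter of repeated measurements. Compound 3 gives 15%, the lowest of the three, yet the gap from compound 1 is also within the scatter. Taken together the three numbers do not separate from one another, and none of the numbers can be called higher or lower than the others beyond the scatter on this evidence.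

The next compound, compound 4, `CCCn1c(=O)[nH]c2nc(-c3ccc(S(=O)(=O)N4CCN(C(C)c5ccccc5)CC4)cc3)[nH]c2c1=O`, is related to compound 1 by one change: 1-phenylethyl in place of 3-chlorophenyl on an amine nitrogen in a ring.

For the measured compounds named here, no step between two measured compounds that differ in one place is known, so there is no precedent in this set against which to size the change. The three measured numbers all sit in the same low band, and nothing in them points to a direction. The step from compound 1 to compound 4 in this assay is therefore expected to be small, a number 2 percentage points lower from compound 1 to compound 4 (within the scatter), with no movement beyond the scatter. Compound 4 is expected to give about 19% in this assay, with a range from 6% to 34%.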

Compound 4, a percentage reported as inhibition, at one concentration (the size of the read-out at that concentration, not a potency): 42%
Estimate against measurement, compound 4: 23 percentage points below, and the stated range ends below it.
By their numbers in this assay, from the lowest: compounds 3, 1 and 2 (each within the scatter of the next); then compound 4.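

In this assay, for the compounds shown here, the group on the amine nitrogen in the ring is the first place where a single change is seen to move the number beyond the scatter: 1-phenylethyl in place of 3-chlorophenyl gives a number 21 percentage points higher from compound 1 to compound 4 (beyond the scatter), a modest step. The swap keeps a six-membered aromatic ring of carbon only and brings no hydrogen-bond donors or acceptors on either side, while an all-carbon group of 8 heavy atoms replaces a chlorine-bearing group of 7, so this position accepts more than one kind of aromatic group without a fall in the number. This single pair cannot separate the loss of chlorine from the gain in carbon, and nothing measured here bears on the reason for the step.

Open, on these data alone, is whether a benzyl or 2-phenylethyl group on the same nitrogen would give a similar number, which would show how much depends on the branching methyl of 1-phenylethyl. A cyclohexyl group or a plain methyl group in that place would test whether the aromatic ring matters at all.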